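One More Carbon on an Ester Chain

This account rests on a few compounds, and the source may have more. Where it says the series, first, only, none or still open, it means among the compounds named here.

In an ADME assay on HFF-1 cells (Homo sapiens) for cytotoxicity, read by MTT assay, with a stated time of 24 h (a lower number here means that less compound is tolerated, a higher number that more compound is tolerated), compound 1 (`CCC(=O)OCCc1ccc(O)c(O)c1`) gives 40 ug/mL and compound 2 (`CCCC(=O)OCCc1ccc(O)c(O)c1`) gives 100 ug/mL, the higher of the two numbers, so more of compound 2 is tolerated. Compound 3 (`CCCCC(=O)OCCc1ccc(O)c(O)c1`) keeps the shared core and alters only the chain of compound 2: methyl in place of hydrogen on a saturated chain carbon, three bonds along the chain from a carbonyl carbon. In other words, propyl becomes butyl. Going by the values given here, one measured step bears on this change: a 2.5-fold higher number from compound 1 to compound 2 (0.40 log units; beyond the scatter), a modest rise for a methyl in place of hydrogen two bonds along the chain from a carbonyl carbon. A single step cannot show whether a rise carries on as the chain grows, so a smaller step in the same direction is the cautious expectation in this assay. The expected change is a 1.7-fold higher number from compound 2 to compound 3 (0.23 log units; within the scatter). Compound 3 is therefore estimated at 170 ug/mL, with an expected range from 70 ug/mL to 400 ug/mL.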

Compound 3, half-maximal cytotoxic concentration: 25 ug/mL
The estimate for compound 3 lay 6.8-fold (0.83 log units) above the measured number; measured number outside the range, below it.
By their numbers in this assay, from the lowest: compounds 3 and 1 (each within the scatter of the next); then compound 2.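

In this assay the same kind of change turns the other way at this position: methyl in place of hydrogen, three bonds along the chain from a carbonyl carbon, gives a 4.0-fold lower number from compound 2 to compound 3 (0.60 log units; beyond the scatter) and so ends the rise seen when ethyl became propyl. Compared directly, the butyl and ethyl chains show a 1.6-fold lower number from compound 1 to compound 3 (0.20 log units; within the scatter) and so cannot be told apart here, which leaves compound 2, with its propyl chain, as the most tolerated of these compounds, its steps to both others lying beyond the scatter. Nothing available explains why the number turns downward at butyl.

As far as these compounds go, whether the number stays low, falls further or recovers with a longer chain such as pentyl remains open. So does the outcome for a branched chain or a chain carrying an amine.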